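A few compounds are considered here, and "the series" means these few. Any claim that something is new, unique, unknown or untested is made for them only; others in the source may bear on it.

Working notes on the series. In a functional assay on LNCaP cells (Homo sapiens) for antiproliferative activity, read by WST assay, with a stated time of 3 days (on this read-out higher numbers stand for weaker inhibition and lower numbers for stronger inhibition), compound 1 (`CCOc1c(-c2cc(OC)c(OC)c(OC)c2)oc2ccccc2c1=O`) gives 5400 nM, compound 2 (`CCCCCOc1c(-c2cc(OC)c(OC)c(OC)c2)oc2ccccc2c1=O`) gives 15400 nM and compound 3 (`CCCC(C)Oc1c(-c2cc(OC)c(OC)c(OC)c2)oc2ccccc2c1=O`) gives 15100 nM. Compound 3 is not separated from compound 2: a 1.0-fold lower number from compound 2 to compound 3 (0.01 log units; within the scatter). Both sit at the high end, with a 2.9-fold higher number from compound 1 to compound 2 (0.46 log units; beyond the scatter) and a 2.8-fold higher number from compound 1 to compound 3 (0.45 log units; beyond the scatter).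

Compound 4 (`CCCN(CCC)CCCCOc1c(-c2cc(OC)c(OC)c(OC)c2)oc2ccccc2c1=O`) has 4-(dipropylamino)butyl in place of 1-methylbutyl on an oxygen on an aromatic ring. Within the data shown here, the measured steps are modest and exchange only nitrogen-free groups, so they bear on this change weakly and this assay offers no direct precedent. The expected move is a 3.0-fold lower number from compound 3 to compound 4 (0.48 log units; beyond the scatter), a modest step toward a lower number, held loosely. Compound 4 is estimated at 5000 nM, with an expected range of 1500 nM to 16000 nM.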

Compound 4, half-maximal inhibitory concentration: 16800 nM
Estimate against measurement, compound 4: 3.4-fold (0.53 log units) below; measured number above the stated range.
By their numbers in this assay, from the lowest: compound 1; then compounds 3, 2 and 4 (each within the scatter of the next).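

Among these compounds, on the oxygen on an aromatic ring, 4-(dipropylamino)butyl, the only nitrogen-bearing group, is not separated from the nitrogen-free chains in this assay: a 1.1-fold higher number from compound 3 to compound 4 (0.05 log units; within the scatter) and a 1.1-fold higher number from compound 2 to compound 4 (0.04 log units; within the scatter). Compound 4 therefore joins compounds 2 and 3 at the high end. The gap to the low end of the series stands at a 3.1-fold higher number from compound 1 to compound 4 (0.49 log units; beyond the scatter). Nothing measured on hand accounts for this result.

Still open, as far as these compounds go, is whether 2-(dipropylamino)ethyl, a dimethylamino or piperidine group on the butyl chain, or a carboxylic acid in place of the amine would move the number.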